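The source may report more compounds than this note shows. Statements on the series, on what has been measured and on what is new or still open speak of the compounds shown alone.

Three compounds measured in an assay on PEO1 cells for inhibition of Retinaldehyde dehydrogenase 3 (Homo sapiens), read by flow cytometry, with a stated time of 30 min, tested at 1 uM (a higher number here means more inhibition at the concentration tested (going by the name of the read-out), a lower number less inhibition), frame this step. Compound 1, `CC(Sc1nc2c(cnn2C)c(=O)n1-c1ccccc1)c1ccccn1`, gives 97%, the highest of the three numbers. Compound 2, `CC(Sc1nc2nn(C3(C)COC3)cc2c(=O)n1-c1ccccc1)c1ccccc1`, gives 90%, a number within the usual scatter of compound 1, so the two cannot be told apart. Compound 3, `Cn1ncc2c(=O)n(-c3ccccc3)c(SCc3cccc(F)c3)cc21`, gives 3%, a number far beyond the scatter below compound 1, showing that changes to the group carried on the sulfur can remove nearly all of the effect.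

The unmeasured compound 4, `CC(Sc1nc2c(cnn2C)c(=O)n1-c1ccccc1)c1cccnc1`, keeps every atom of compound 1 but joins them differently: pyridin-3-yl in place of pyridin-2-yl on a saturated chain carbon bound to a saturated chain carbon and a sulfur. For the measured compounds named here, no step between two measured compounds matches this change, so its size and direction cannot be read off directly from the measured pairs.

Because compound 1 reaches 97% and compound 2, with a different group on that carbon, still gives 90%, the expectation is that compound 4 stays strongly inhibiting, with a step of a number 15 percentage points lower from compound 1 to compound 4 (beyond the scatter) that may be no larger than the scatter but could lean downward. The estimate for compound 4 in this assay is 82%, expected to fall between 45% and 98%.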

Compound 4, a percentage reported as inhibition, at one concentration (the size of the read-out at that concentration, not a potency): 95%
Compound 4: middle estimate off by 13 percentage points, on the low side; measured number inside the range.
By their numbers in this assay, from the lowest: compound 3; then compounds 2, 4 and 1 (each within the scatter of the next).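

In this assay, putting pyridin-3-yl in place of pyridin-2-yl on a saturated chain carbon bound to a saturated chain carbon and a sulfur gives a number 2 percentage points lower from compound 1 to compound 4 (within the scatter), so the two compounds cannot be told apart. For the compounds shown here, this is the first pair here that differs in one place, and it shows that the point at which the pyridine ring is attached can change with no readable effect on inhibition at the tested concentration. Nothing available explains why the two compounds read alike.

From the compounds shown here alone, whether the pyridine nitrogen matters at all remains open, as does whether a pyridin-4-yl group, a plain phenyl ring or a carboxylic acid on that same carbon would keep the inhibition. A reading at one concentration gives the size of the effect rather than a potency, so compound 1 and compound 4 could still prove different in a full concentration series.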